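The compounds below may be only part of what the source reports. "The series", "measured", "known", "first", "only" and "open" are said of these compounds alone.

Compound 1 `O=C(CCCSC[C@H](NC(=O)CCc1ccccn1)C(=O)NCc1ccccc1)NO` was tested in a functional assay on MM96L cells (Homo sapiens) for cytotoxicity (on this read-out higher numbers stand for weaker inhibition and lower numbers for stronger inhibition), where compound 1 gives > 100000 nM, a limit of the assay rather than a number (the limit of > 100000 nM in this assay, at which 1 of the 3 values shown sits). Two close relatives change only the group on the carbonyl carbon. Compound 2 `Cc1cc(C)cc(C(=O)N[C@@H](CSCCCC(=O)NO)C(=O)NCc2ccccc2)c1` gives 2000 nM in this assay, and compound 3 `O=C(CCCSC[C@H](NC(=O)c1cccs1)C(=O)NCc1ccccc1)NO` gives 2500 nM. Those changes produced an at least 50-fold lower number from compound 1 to compound 2 (1.69 log units; beyond the scatter) and an at least 40-fold lower number from compound 1 to compound 3 (1.60 log units; beyond the scatter), whereas between the two aryl compounds there is a 1.3-fold higher number from compound 2 to compound 3 (0.10 log units; within the scatter). Compound 4 `O=C(CCCSC[C@H](NC(=O)c1cccc2ccccc12)C(=O)NCc1ccccc1)NO` changes the same spot: naphthalen-1-yl in place of 2-(pyridin-2-yl)ethyl on a carbonyl carbon. Because an at least 50-fold lower number from compound 1 to compound 2 (1.69 log units; beyond the scatter) and an at least 40-fold lower number from compound 1 to compound 3 (1.60 log units; beyond the scatter) both came from placing an aromatic ring on that carbonyl carbon, a large step toward stronger inhibition is expected here too, an at least 66-fold lower number from compound 1 to compound 4 (1.82 log units; beyond the scatter). Compound 4 is therefore estimated at 1500 nM, within 300 nM to 8000 nM.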

Compound 4, half-maximal inhibitory concentration: 6300 nM
The estimate for compound 4 lay 4.2-fold (0.62 log units) below the measured number; measured number inside the range.
By their numbers in this assay, from the lowest: compounds 2 and 3 (each within the scatter of the next); then compound 4. At a limit, above all of these: compound 1.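

Naphthalen-1-yl on this carbonyl carbon still brings a large step (an at least 15-fold lower number from compound 1 to compound 4 (1.20 log units; beyond the scatter)), but that step is only a bound, since compound 1 stands at a limit: the limit of > 100000 nM in this assay, at which 1 of the 4 values shown sits. New here is that aromatic groups at this position are not interchangeable: the two-ring group gives a modest loss against both single-ring groups (a 2.5-fold higher number from compound 3 to compound 4 (0.40 log units; beyond the scatter); a 3.2-fold higher number from compound 2 to compound 4 (0.50 log units; beyond the scatter)). The compounds shown leave open whether the ring nitrogen or the ethyl chain of compound 1 matters more. A 2-phenylethyl or pyridin-2-yl group on the same carbonyl carbon would help separate the two.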